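The compounds below may be only part of what the source reports. "The series", "measured", "known", "first", "only" and "open" are said of these compounds alone.

Measured compounds:
Compound 1 `O=Cc1ccc(-c2cn3ccnc3c(-c3ccc4ncn(C5CCCCC5)c4c3)n2)cc1`: 20.9%
Compound 2 `CCc1ccc(-c2cn3ccnc3c(-c3ccc4ncn(Cc5ccccc5)c4c3)n2)cc1`: 39.7%
Compound 3 `Cc1cccc(-c2cn3ccnc3c(-c3ccc4ncn(Cc5ccccc5)c4c3)n2)c1`: 22.3%

In a functional assay on EKVX cells (Homo sapiens) for inhibition, read by sulforhodamine B assay, with a stated time of 48 h, tested at 10 uM (on this read-out lower numbers stand for less inhibition and higher numbers for more inhibition at the one concentration tested (going by the name of the read-out)), compound 3 stands second highest of the three numbers. Its nearest neighbour is compound 1, whose value lies within the scatter of that of compound 3, so no order between the two can be read. For the measured compounds named here, the furthest is compound 2, and the one measured step, a number 17.4 percentage points lower from compound 2 to compound 3 (beyond the scatter), lies beyond the scatter.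

The step now followed leads from compound 3 to compound 4 `O=Cc1ccc(-c2cn3ccnc3c(-c3ccc4ncn(Cc5ccccc5)c4c3)n2)cc1`. The change is 4-formylphenyl in place of 3-methylphenyl on an aromatic carbon. Going by the values given here, no measured step covers this exact exchange, so the account rests on what the values show. Compound 1 carries the same 4-formylphenyl group on a core that differs from that of compound 4 only in the group on the other side, and in this assay compound 1 gives 20.9%, which lies within the scatter of compound 3. Among the compounds with values here, the only step beyond the scatter, a number 17.4 percentage points lower from compound 2 to compound 3 (beyond the scatter), concerns a different pair of groups and does not bear directly on this exchange.

For compound 4 the expected step is a number 0.3 percentage points lower from compound 3 to compound 4 (within the scatter), that is, no change beyond the scatter. Compound 4 is therefore estimated at 22%, with a range from 8% to 38%.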

Compound 4, a percentage reported as inhibition, at one concentration (the size of the read-out at that concentration, not a potency): 20.9%
Beside the measured number, compound 4's estimate is 1.1 percentage points above it; measured number inside the range.
By their numbers in this assay, from the lowest: compounds 1, 4 and 3 (each within the scatter of the next); then compound 2.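

In this assay, the exchange of 3-methylphenyl for 4-formylphenyl gives a number 1.4 percentage points lower from compound 3 to compound 4 (within the scatter), while formyl in place of ethyl gives a number 18.8 percentage points lower from compound 2 to compound 4 (beyond the scatter); the earlier drop from the 4-ethylphenyl compound therefore also appears with a group that keeps the 4-substituted phenyl name, so it does not depend on a 3-substituted phenyl group, and among the three benzyl compounds only compound 2 stands apart. For the compounds shown here, the result also gives the first reading of the group on the aromatic nitrogen: benzyl in place of cyclohexyl gives no change at the digits printed from compound 1 to compound 4 (within the scatter), so with 4-formylphenyl in place, this exchange shows no difference in this read-out. No supporting measurement is available to explain why ethyl stands apart from formyl at this place.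

Going by these compounds, whether a longer chain such as propyl on the phenyl ring would follow the 4-ethylphenyl compound, or whether an amine or a carboxylic acid would follow the 4-formylphenyl compound, remains open. It is also open whether cyclohexyl and benzyl would still match with 4-ethylphenyl in place of 4-formylphenyl, since the pair shown rests on the formyl compounds alone.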